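Pyridine nitrogen shift in the sulfonyl series

The compounds below may be only part of what the source reports. "The series", "measured", "known", "first", "only" and "open" are said of these compounds alone.

compound 1 `O=C1/C(=C/c2cccnc2)CN(S(=O)(=O)c2ccc(C(F)(F)F)cc2)C/C1=C\c1ccccc1C(F)(F)F` gives 1500 nM
compound 2 `O=C1/C(=C/c2cccnc2)CN(S(=O)(=O)c2ccc(Cl)cc2)C/C1=C\c1ccccc1C(F)(F)F` gives 3440 nM
compound 3 `CC(=O)Nc1ccc(S(=O)(=O)N2C/C(=C\c3cccnc3)C(=O)/C(=C/c3ccccc3C(F)(F)F)C2)cc1` gives 5380 nM

All three values come from a functional assay on QGY-7703 cells (Homo sapiens) for cytotoxicity, read by MTT assay, with a stated time of 24 h (a lower number here means a stronger inhibitor, a higher number a weaker inhibitor), and compound 1 stands lowest of them. The steps to the other two lie beyond the scatter (a 2.3-fold higher number from compound 1 to compound 2 (0.36 log units; beyond the scatter) and a 3.6-fold higher number from compound 1 to compound 3 (0.55 log units; beyond the scatter)). Compound 2 and compound 3 sit within the scatter of each other (a 1.6-fold higher number from compound 2 to compound 3 (0.19 log units; within the scatter)).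

Compound 4 `O=C1/C(=C/c2ccncc2)CN(S(=O)(=O)c2ccc(C(F)(F)F)cc2)C/C1=C\c1ccccc1C(F)(F)F` has not yet been measured. It differs from compound 1 in one place: pyridin-4-yl in place of pyridin-3-yl on a double-bonded chain carbon bound to a double-bonded ring carbon and so pyridin-4-yl stands in place of pyridin-3-yl on a double-bonded chain carbon bound to a double-bonded ring carbon.

Among the measured compounds shown here, none of the measured steps touches this place. All three exchange trifluoromethyl, chloro or acetamido on an aromatic carbon elsewhere in the molecule, so they give only a rough idea of how far values move in this series, and that movement is modest at most. The data hold no direct comparison of the two pyridinyl groups, which leaves the range wide. For the measured compounds named here, the expected step in this assay is a 1.2-fold higher number from compound 1 to compound 4 (0.08 log units; within the scatter) and so none beyond the scatter, with a slight lean upward as compound 1 is the lowest value so far. Compound 4 is estimated at 1800 nM with 800 nM to 4000 nM as the expected range.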

Compound 4, half-maximal inhibitory concentration: 4680 nM
Compound 4: the middle estimate sits 2.6-fold (0.41 log units) below what was measured, and the stated range ends below it.
By their numbers in this assay, from the lowest: compound 1; then compounds 2, 4 and 3 (each within the scatter of the next).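

Among the compounds shown here, the place on the double-bonded chain carbon bound to a double-bonded ring carbon is not silent: in this assay, moving only the ring nitrogen gives a 3.1-fold higher number from compound 1 to compound 4 (0.49 log units; beyond the scatter) and is the first measured change at this place. Heavy atoms, hydrogen-bond donors and acceptors, and net charge are all counted the same for pyridin-3-yl and pyridin-4-yl, so those counts do not separate the two groups, yet this step is classed as modest and beyond the scatter, as is a 3.6-fold higher number from compound 1 to compound 3 (0.55 log units; beyond the scatter) at the aromatic carbon carrying trifluoromethyl in compound 1. On the core of compound 1, pyridin-3-yl therefore gives the lower number of the two pyridinyl groups, and this place matters in this series alongside the aromatic-carbon substituent. The data on hand offer no measurement that accounts for the difference between the two pyridinyl groups.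

For the compounds shown here, whether the same preference for pyridin-3-yl holds with chloro or acetamido in place of trifluoromethyl remains open, as only the one pair of pyridinyl isomers is available. Also open, from the compounds shown here alone, is how pyridin-2-yl or a plain phenyl group would sit against these two at the same place.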